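Working notes: bromo on the shared core, compound 4

The source may report more compounds than this note shows. Statements on the series, on what has been measured and on what is new or still open speak of the compounds shown alone.

Compound 1 `CO[C@@H]1[C@H](N(C)c2ncc(-c3c[nH]c4ccc(F)cc34)s2)C[C@H]2O[C@]1(C)n1c3ccccc3c3c4c(c5c6ccccc6n2c5c31)C(=O)NC4`, compound 2 `CO[C@@H]1[C@H](N(C)c2ncc(-c3c[nH]c4ccc(Cl)cc34)s2)C[C@H]2O[C@]1(C)n1c3ccccc3c3c4c(c5c6ccccc6n2c5c31)C(=O)NC4` and compound 3 `COc1ccc2[nH]cc(-c3cnc(N(C)[C@@H]4C[C@H]5O[C@@](C)([C@@H]4OC)n4c6ccccc6c6c7c(c8c9ccccc9n5c8c64)C(=O)NC7)s3)c2c1` share one core and differ only in a single group on an aromatic carbon. In a functional assay on MV4-11 cells (Homo sapiens) for antiproliferative activity, read by CellTiter-Glo, with a stated time of 72 h (a lower number here means a stronger inhibitor, a higher number a weaker inhibitor), compound 1 gives 510 nM, compound 2 gives 420 nM and compound 3 gives 360 nM. Compound 2 stands second highest of the three numbers; the step of a 1.2-fold lower number from compound 2 to compound 3 (0.07 log units; within the scatter) and the step of a 1.2-fold lower number from compound 1 to compound 2 (0.08 log units; within the scatter) both sit within the scatter, as does the step of a 1.4-fold lower number from compound 1 to compound 3 (0.15 log units; within the scatter), so the three values form one group.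

Compound 4 `CO[C@@H]1[C@H](N(C)c2ncc(-c3c[nH]c4ccc(Cl)cc34)s2)C[C@H]2O[C@]1(C)n1c3ccccc3c3c4c(c5c6cc(Br)ccc6n2c5c31)C(=O)NC4` keeps the chloro of compound 2 and adds one change: bromo in place of hydrogen on an aromatic carbon, placed on a six-membered aromatic ring of carbon only that is part of the fused system of eight rings, meta to a fused ring and para to a fused ring. Among the measured compounds shown here, none of the three measured steps touches this part of the core; each of them exchanges a group elsewhere and stays within the scatter, so no measured step gives the size or direction of this change in this assay. The estimate for compound 4 is set near compound 2, at 420 nM, with a wide range from 130 nM to 1300 nM. The step this estimate means, no change at the digits printed from compound 2 to compound 4 (within the scatter), is expected to stay within the scatter, the range open in both directions.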

Compound 4, half-maximal inhibitory concentration: 700 nM
The estimate for compound 4 lay 1.7-fold (0.22 log units) below the measured number, within the range that was stated.
By their numbers in this assay, from the lowest: compounds 3, 2, 1 and 4 (each within the scatter of the next).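

In this assay, among the compounds shown here, bromo in place of hydrogen on an aromatic carbon, meta to a fused ring and para to a fused ring, gives a 1.7-fold higher number from compound 2 to compound 4 (0.22 log units; within the scatter), the first measured step at this part of the shared core, as the earlier steps all exchange a group elsewhere. Since this step lies within the scatter, it assigns no direction to the change; it shows only that, with the chloro of compound 2 in place, this one added bromo leaves compound 4 within the scatter of compound 2. Nothing measured here accounts for the size of this step.

Open, from the compounds shown here alone, is whether bromo at this carbon gives a step of similar size with the fluoro of compound 1 or the methoxy of compound 3 in place of the chloro. For the compounds shown here, also open is whether an amine, a carboxylic acid or a longer chain at this same carbon would give a step beyond the scatter, which the single bromo compound cannot indicate.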